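Hydroxy-to-fluoro swap on the shared quinoline-derived core

The source may hold more compounds than are shown below. What is called first, only, known or untested is meant among the compounds shown, and "the series" means these compounds.

Measured so far:
- compound 1, `CN(C)c1ccc2c(O)c(C(=O)O)cnc2c1`, 372000 nM in an assay on isolated protein with malate dehydrogenase, cytoplasmic (Sus scrofa) as the target; a lower number here means a stronger inhibitor, a higher number a weaker inhibitor
- compound 2, `O=C(O)c1cnc2cc(O)ccc2c1O`, 955000 nM in this assay

For the measured compounds named here, compound 2 stands highest of the two numbers so far; its nearest neighbour is compound 1, and the one measured step, a 2.6-fold higher number from compound 1 to compound 2 (0.41 log units; beyond the scatter), is modest but beyond the scatter. Compound 3, `O=C(O)c1cnc2cc(F)ccc2c1O`, is not yet measured in this assay. It differs from compound 2 by fluoro in place of hydroxy on an aromatic carbon. Going by the values given here, no measured step bears directly on this change: the only step known concerns a hydroxy arriving in place of dimethylamino, not a hydroxy leaving for a fluoro, so its size carries little over. With both measured numbers lying in the same high region, compound 3 is expected to land close to compound 2, with no step beyond the scatter, that is a 1.2-fold lower number from compound 2 to compound 3 (0.08 log units; within the scatter). The estimate for compound 3 in this assay is 800000 nM, within 250000 nM to 2500000 nM.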

Compound 3, half-maximal inhibitory concentration: 11000000 nM
For compound 3 the middle estimate is 14-fold (1.14 log units) below the measured one; measured number above the stated range.
By their numbers in this assay, from the lowest: compound 1; then compound 2; then compound 3.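

In this assay this aromatic carbon proves far from indifferent: fluoro in place of hydroxy gives a 12-fold higher number from compound 2 to compound 3 (1.06 log units; beyond the scatter), a larger step than the earlier hydroxy in place of dimethylamino. Fluoro in place of dimethylamino on the same carbon gives a 30-fold higher number from compound 1 to compound 3 (1.47 log units; beyond the scatter), the largest step so far in the series. Among these three compounds the numbers rise from dimethylamino through hydroxy to fluoro, with every step beyond the scatter, and no compound shown goes against that order.

As far as these compounds go, whether a primary amine, a methoxy group or a chloro group on this carbon would fall nearer compound 1 or nearer compound 3 remains open, as does whether the order holds on a core without the carboxylic acid. No measurement at hand accounts for the size of these steps.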